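This account rests on a few compounds, and the source may have more. Where it says the series, first, only, none or still open, it means among the compounds named here.

Compound 1 `OC[C@H]1O[C@@H](n2cnc3c(Sc4ccccc4)ncnc32)[C@H](O)[C@@H]1O` gives 91200 nM in an assay on isolated protein for binding affinity to Equilibrative nucleoside transporter 1 (Homo sapiens); on this read-out higher numbers stand for weaker inhibition and lower numbers for stronger inhibition.
Compound 2 `OC[C@H]1O[C@@H](n2cnc3c(CSc4ccc(Br)cc4)ncnc32)[C@H](O)[C@@H]1O` gives 178 nM in this assay.

Compound 2 stands at the lower of these two numbers. Among the measured compounds shown here, the only measured step, a 510-fold lower number from compound 1 to compound 2 (2.71 log units; beyond the scatter), is large, but it changes two things at once and does not isolate the halogen. Compound 3 `OC[C@H]1O[C@@H](n2cnc3c(CSc4ccc(F)cc4)ncnc32)[C@H](O)[C@@H]1O` differs from compound 2 by fluoro in place of bromo on an aromatic carbon. For the measured compounds named here, no measured step bears directly on this exchange, so its direction is not fixed by the data. The expected step is a 2.0-fold higher number from compound 2 to compound 3 (0.29 log units; within the scatter), within the usual scatter or a modest rise. Compound 3 is therefore estimated at 350 nM, with a range from 120 nM to 1100 nM.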

Compound 3, half-maximal inhibitory concentration: 158 nM
For compound 3 the middle estimate is 2.2-fold (0.35 log units) above the measured one; measured number inside the range.
By their numbers in this assay, from the lowest: compounds 3 and 2 (each within the scatter of the next); then compound 1.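

In this assay, fluoro in place of bromo on the aromatic carbon para to a large group gives a 1.1-fold lower number from compound 2 to compound 3 (0.05 log units; within the scatter), so this exchange of halogens makes no difference beyond the scatter. The large step from the earlier comparison also holds with fluoro, at a 580-fold lower number from compound 1 to compound 3 (2.76 log units; beyond the scatter), though this step again changes two things at once. Nothing available gives a reason for either result.

Still open, on these data alone, is what a methoxy group or an amine would do in place of the halogen. Also open, as far as these compounds go, is how much of the large step comes from the methyl link and how much from the halogen.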